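A few compounds are considered here, and "the series" means these few. Any claim that something is new, unique, unknown or untested is made for them only; others in the source may bear on it.

Compound 1 `COc1cc(OC)c2c(=O)cc(/C=C/c3ccc([N+](=O)[O-])cc3)oc2c1` was tested in a functional assay on HeLa cells (Homo sapiens) for antiproliferative activity, read by MTT assay, with a stated time of 12 h (a higher number here means a weaker inhibitor, a lower number a stronger inhibitor), and gives 9600 nM. Among the compounds with values here, the only other compound measured here is compound 2 `COc1ccc2oc(/C=C/c3ccc(OC(F)(F)F)cc3)cc(=O)c2c1`, which in this assay gives 9000 nM. The two numbers lie within the usual scatter of each other, so neither can be called weaker or stronger; compound 1 simply sits alongside compound 2 at the micromolar end of what has been measured.

Compound 3 `COc1cc(OC)c2c(=O)cc(/C=C/c3ccc(Cl)cc3)oc2c1` shares the core of compound 1 and differs from it in one place: chloro in place of nitro on an aromatic carbon. Within the data shown here, no pair of measured compounds shows what this particular exchange does, so the size of the step can only be expected rather than read off. With nothing to point either way, the step from compound 1 to compound 3 in this assay is expected to be small, a 1.2-fold lower number from compound 1 to compound 3 (0.08 log units; within the scatter), and not clearly beyond the scatter. Compound 3 is therefore estimated at 8000 nM, within a range from 3000 nM to 25000 nM.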

Compound 3, half-maximal inhibitory concentration: 14200 nM
For compound 3 the middle estimate is 1.8-fold (0.25 log units) below the measured one, within the range that was stated.
By their numbers in this assay, from the lowest: compounds 2, 1 and 3 (each within the scatter of the next).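

In this assay, chloro in place of nitro on an aromatic carbon gives a 1.5-fold higher number from compound 1 to compound 3 (0.17 log units; within the scatter) and so cannot be told apart from compound 1 by this read-out. Within the data shown here, this is the first direct look at this position, para to a large group, and it shows that nitro, with its hydrogen-bond acceptors, and the single-atom chloro, with none, give readings within the scatter on the shared core. Nothing measured here offers an explanation for how closely these two readings agree.

As far as these compounds go, whether any group at this position can move the number beyond the scatter remains open, for instance an amine or a carboxylic acid. A single pair also cannot show whether the same exchange would behave alike on a different core.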